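Benzyl for Phenyl on the Amide Nitrogen of Compound 2

The source may hold more compounds than are shown below. What is called first, only, known or untested is meant among the compounds shown, and "the series" means these compounds.

Compounds measured so far:
Compound 1, `CC(Sc1nnc(-c2ccncc2)s1)C(=O)NCc1ccc(Cl)cc1`: "not determined" (no result reported) in an ADME assay on HepG2 cells (Homo sapiens) for cytotoxicity, with a stated time of 3 days; a lower number here means that less compound is tolerated, a higher number that more compound is tolerated
Compound 2, `CC(CSc1nnc(-c2ccncc2)s1)C(=O)Nc1ccccc1Cl`: > 50000 nM
Compound 3, `CC(CSc1nnc(-c2ccncc2)s1)C(=O)NCc1ccccc1Cl`: not yet measured

In this assay compound 2 gives > 50000 nM, which is a limit of the assay and not a number. Compound 2 thus sits at the limit of > 50000 nM in this assay, at which 1 of the 2 values shown sits, and nothing more precise is known of it. Among the measured compounds shown here, compound 1 carries no reported result in this assay, so the two measured entries give no step between measured compounds to learn from.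

Compound 3 differs from compound 2 in one place: 2-chlorobenzyl in place of 2-chlorophenyl on an amide-type nitrogen. For the measured compounds named here, no measured step shows how this change acts here. The expected step of a number no higher from compound 2 to compound 3 (the limit leaves the size open) is taken as none beyond the usual scatter, in either direction. Compound 3 is therefore expected to give 50000 nM, within 20000 nM to 100000 nM, most probably again reported only as a limit in this assay.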

Compound 3, half-maximal cytotoxic concentration: > 50000 nM
Compound 3 ended at the assay's limit; the forecaster's own chance of this, stated with the estimate: 75%; the middle value lies on the limit itself.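

In this assay compound 2 and compound 3 both end at a limit, so no step can be read between them: the limit of > 50000 nM in this assay, at which 2 of the 3 values shown sit.

The compounds shown leave open whether 2-chlorobenzyl in place of 2-chlorophenyl on an amide-type nitrogen changes the tolerated concentration at all.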